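A few compounds are considered here, and "the series" means these few. Any claim that something is new, unique, unknown or untested is made for them only; others in the source may bear on it.

In an ADME assay (liver) for metabolic stability, with Liver microsome (Rattus norvegicus) as the target, using microsomes and NADPH, with a stated time of 30 min, at 37 degrees C, tested at 1 uM (a lower number here means slower removal, a higher number faster removal of the compound), compound 1 `Nc1ccc(S(=O)(=O)c2ccc(-c3ncc(C(O)(C(F)(F)F)C(F)(F)F)cc3Cl)cc2)cn1` gives 18 mL.min-1.g-1 and compound 2 `Nc1ccc(S(=O)(=O)c2ccc(-c3ncc(C(O)(C(F)(F)F)C(F)(F)F)cc3C#CCO)cc2)cn1` gives 36 mL.min-1.g-1. Compound 3 `COCC#Cc1cc(C(O)(C(F)(F)F)C(F)(F)F)cnc1-c1ccc(S(=O)(=O)c2ccc(N)nc2)cc1` reaches only a limit of the assay, not a number: > 399 mL.min-1.g-1. Compound 4 `C[C@H](O)C#Cc1cc(C(O)(C(F)(F)F)C(F)(F)F)cnc1-c1ccc(S(=O)(=O)c2ccc(N)nc2)cc1` has the same atoms joined differently, with 1-hydroxyethyl in place of methoxymethyl on a triple-bonded carbon. The closest measured step is the one that places methyl on the oxygen, an at least 11-fold higher number from compound 2 to compound 3 (1.04 log units; beyond the scatter), and an at least 22-fold higher number from compound 1 to compound 3 (1.34 log units; beyond the scatter) is also large, whereas a 2.0-fold higher number from compound 1 to compound 2 (0.30 log units; within the scatter) stays within the scatter. Compound 4 carries a free hydroxyl, as does compound 2 at 36 mL.min-1.g-1, so a large fall is expected in this assay, with the expected step being an at least 7.9-fold lower number from compound 3 to compound 4 (0.90 log units; beyond the scatter). The estimated value for compound 4 is 50 mL.min-1.g-1, with an expected range of 18 mL.min-1.g-1 to 150 mL.min-1.g-1.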

Compound 4, intrinsic clearance in microsomes: 29 mL.min-1.g-1
The estimate for compound 4 lay 1.7-fold (0.24 log units) above the measured number; measured number inside the range.
By their numbers in this assay, from the lowest: compounds 1, 4 and 2 (each within the scatter of the next). At a limit, above all of these: compound 3.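

In this assay, the same atoms joined as 1-hydroxyethyl rather than methoxymethyl on a triple-bonded carbon give an at least 13-fold lower number from compound 3 to compound 4 (1.13 log units; beyond the scatter). That step starts from a limit held by compound 3, not from a number: the limit of > 399 mL.min-1.g-1 in this assay, at which 1 of the 4 values shown sits. Methyl on the saturated chain carbon shifts nothing readable, with a 1.2-fold lower number from compound 2 to compound 4 (0.09 log units; within the scatter), and the new chain also stays level with chloro, with a 1.6-fold higher number from compound 1 to compound 4 (0.21 log units; within the scatter), both within the scatter.

Open, going by these compounds, is whether the opposite stereocentre of compound 4 would read alike. Also open, on these data alone, is whether an amine or a carboxylic acid in place of the hydroxyl would stay level with compound 2.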